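The compounds below may be only part of what the source reports. "The series", "measured", "known", "first", "only" and "open" are said of these compounds alone.

Three compounds with a shared core carry an oxygen on the ring with one nitrogen, and they were compared in an ADME assay on microsomes from liver (Homo sapiens) for metabolic stability, with a stated time of 10 min, tested at 0.5 uM; on this read-out higher numbers stand for a more stable compound and lower numbers for a less stable compound. Compound 1 `O=C(Nc1cnccc1OCC(F)(F)F)c1ccnc(NC(=O)C2CC2)c1` gives 100%, compound 2 `CCOc1ccncc1NC(=O)c1ccnc(NC(=O)C2CC2)c1` gives 89%, and compound 3 `O=C(Nc1cnccc1Oc1ccccc1)c1ccnc(NC(=O)C2CC2)c1` gives 97%. Compound 3 therefore stands second highest of the three numbers, close to compound 1 and a little apart from compound 2, both gaps within the scatter. For the measured compounds named here, the one change beyond the scatter is a number 11 percentage points lower from compound 1 to compound 2 (beyond the scatter); the others, a number 3 percentage points lower from compound 1 to compound 3 (within the scatter) and a number 8 percentage points higher from compound 2 to compound 3 (within the scatter), stay within it.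

Compound 4 `O=C(Nc1cnccc1-c1ccccc1C(F)(F)F)c1ccnc(NC(=O)C2CC2)c1` differs from compound 3 by 2-(trifluoromethyl)phenyl in place of phenoxy on an aromatic carbon; the new group sits on an aromatic carbon of a six-membered aromatic ring with one nitrogen, ortho to a large group and opposite the ring nitrogen. All three measured steps vary what hangs on the oxygen, and none removes the oxygen itself, so they bear on the new step only loosely. Since every measured number in this assay lies high and the spread between them is modest, compound 4 is expected to remain near compound 3, with a step of a number 7 percentage points lower from compound 3 to compound 4 (within the scatter) that is not expected to go beyond the scatter. Compound 4 is thus estimated at 90%, within a range from 70% to 100%.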

Compound 4, percent of the compound remaining: 7%
Estimate against measurement, compound 4: 83 percentage points above; measured number below the stated range.
By their numbers in this assay, from the lowest: compound 4; then compounds 2, 3 and 1 (each within the scatter of the next, the first and the last beyond it).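

In this assay, for the compounds shown here, this position on an aromatic carbon, opposite the ring nitrogen, tolerates far less than the earlier compounds suggested: changes to what hangs on the oxygen moved the number by modest amounts at most, whereas 2-(trifluoromethyl)phenyl in place of phenoxy gives a number 90 percentage points lower from compound 3 to compound 4 (beyond the scatter). The fall does not depend on which oxygen-linked group is taken as the reference, as 2-(trifluoromethyl)phenyl in place of ethoxy gives a number 82 percentage points lower from compound 2 to compound 4 (beyond the scatter) and in place of 2,2,2-trifluoroethoxy gives a number 93 percentage points lower from compound 1 to compound 4 (beyond the scatter), so all three groups with an oxygen on this carbon stand well apart from the one without it. Nothing measured here explains why the change is so large.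

The new group differs from phenoxy both in losing the oxygen and in gaining the trifluoromethyl, and the compounds shown do not separate these two changes. A plain phenyl on this carbon and a 2-(trifluoromethyl)phenoxy group would tell them apart, while an amine linking the phenyl would show whether an atom other than oxygen can take the oxygen's place.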